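This account rests on a few compounds, and the source may have more. Where it says the series, first, only, none or still open, it means among the compounds named here.

Of the compounds shown here, three that share a similar core have been tested in a functional assay on the whole organism with Mus musculus as the target, in the rotarod test; on this read-out higher numbers stand for an effect only at larger amounts of compound and lower numbers for an effect already at smaller amounts. Compound 1 `CCN(C)C(=O)/C=C1\CCc2c(F)cc(F)cc21` gives 73 mg/kg and compound 2 `CCNC(=O)/C=C1\CCc2ccc(F)cc21` gives 136 mg/kg, two numbers within the usual scatter of each other. Compound 3 `NC(=O)/C=C1\CCc2ccc(Cl)cc21` gives 221 mg/kg, which lies beyond the scatter above the number for compound 1, so compound 1 stands at the low-dose side of that pair.

Compound 4 `CC(C)NC(=O)/C=C1\CCc2c(F)cc(F)cc21` has not yet been measured. It keeps the core of compound 1, but isopropylamino takes the place of ethyl(methyl)amino on a carbonyl carbon (isopropylamino in place of ethyl(methyl)amino on a carbonyl carbon). Compound 4 therefore has an amide hydrogen, which compound 1 lacks. Among the measured compounds shown here, no measured pair shows this change alone, so any forecast is loose. Compound 2 also carries an amide hydrogen and gives 136 mg/kg, within the scatter of compound 1, so only a small change is expected. The expected step is a 1.4-fold higher number from compound 1 to compound 4 (0.14 log units; within the scatter), a slight rise that stays within the scatter. For compound 4 the estimated value is 100 mg/kg, with an expected range from 50 mg/kg to 200 mg/kg.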

Compound 4, dose for half-maximal effect: 76 mg/kg
Estimate against measurement, compound 4: 1.3-fold (0.12 log units) above; measured number inside the range.
By their numbers in this assay, from the lowest: compounds 1, 4, 2 and 3 (each within the scatter of the next, the first and the last beyond it).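

Among the compounds shown here, compound 1 and compound 4 form the only pair here that differs in one place, and in this assay isopropylamino in place of ethyl(methyl)amino on a carbonyl carbon gives a 1.0-fold higher number from compound 1 to compound 4 (0.02 log units; within the scatter) and so leaves no readable difference. For the compounds shown here, this gives the first direct reading of this position: on this core, the amide hydrogen that isopropylamino brings and ethyl(methyl)amino lacks goes with no visible shift in the number. No further evidence on this result is available.

Still open, on these data alone, is whether a clearly different group on the same carbonyl carbon, such as a longer chain like hexylamino or a ring amine like morpholine, would also leave the number in place. Also open, as far as these compounds go, is whether the same swap would read alike on the core of compound 2.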